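The source may report more compounds than this note shows. Statements on the series, on what has been measured and on what is new or still open speak of the compounds shown alone.

This account follows a series built on one shared core, examined in an ADME assay on L6 cells (Rattus norvegicus) for cytotoxicity, read by resazurin assay, with a stated time of 70 h; on this read-out lower numbers stand for stronger inhibition and higher numbers for weaker inhibition. Compound 1, `COc1cc(NC(C)CCCNC(=O)NCCO)c2ncccc2c1`, is part of the set, but in this assay compound 1 has the outcome "not determined" (no result reported), so no number exists for it. Going by the values given here, compound 2, `COc1ccc(/C=C/C(=O)NNC(=O)NCCCC(C)Nc2cc(OC)cc3cccnc23)cc1`, is the only compound with a measured figure: in this assay compound 2 gives 3600 nM, and it therefore stands alone, with one further entry lacking a single number. Compound 3, `COc1cc(NC(C)CCCNC(=O)NNC(=O)Nc2ccc(C(F)(F)F)cc2)c2ncccc2c1`, has not yet been measured in this assay. It differs from compound 2 in one place: (4-(trifluoromethyl)phenyl)amino in place of 2-(4-methoxyphenyl)ethenyl on a carbonyl carbon. Among the compounds with values here, no step between measured compounds exists to guide the direction, so the expected change from compound 2 to compound 3 is a small one, a 1.1-fold higher number from compound 2 to compound 3 (0.05 log units; within the scatter), not beyond the scatter. Compound 3 is expected to show about 4000 nM in this assay, between 1500 nM and 12000 nM.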

Compound 3, half-maximal inhibitory concentration: 14900 nM
Beside the measured number, compound 3's estimate is 3.7-fold (0.57 log units) below it, and the stated range ends below it.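

In this assay, going by these compounds alone, the change on this carbonyl carbon, whose other neighbour is an amide-type nitrogen, is not a silent one: (4-(trifluoromethyl)phenyl)amino in place of 2-(4-methoxyphenyl)ethenyl gives a 4.1-fold higher number from compound 2 to compound 3 (0.62 log units; beyond the scatter), the only step the series offers here. The number moves even though the leaving and the entering group each carry one six-membered aromatic ring of carbon only, so the position responds to what else changes in the group. Nothing available explains this rise.

A single step cannot separate the loss of the ethenyl double bond and the methoxy oxygen from the entry of the amino nitrogen and the trifluoromethyl group. Open too, going by these compounds, is how (4-methoxyphenyl)amino or a carboxylic acid would read on the same carbonyl carbon.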